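The source may hold more compounds than are shown below. What is called first, only, known or untested is meant among the compounds shown, and "the series" means these compounds.

Compound 1, `C[C@H]1O[C@@H](n2cnc3c(N)nc(Cl)nc32)[C@H](O)[C@@H]1O`: 147000 nM
Compound 2, `CS[C@H]1O[C@@H](n2cnc3c(N)nc(Cl)nc32)[C@H](O)[C@@H]1O`: 271000 nM
Compound 3, `C[C@H]1O[C@@H](n2cnc3c(N)nc(NN)nc32)[C@H](O)[C@@H]1O`: 188000 nM

All three values come from an ADME assay on L6 cells (Rattus norvegicus) for cytotoxicity; on this read-out higher numbers stand for weaker inhibition and lower numbers for stronger inhibition. Compound 2 differs from compound 1 by methylsulfanyl in place of methyl on a saturated ring carbon; in this assay that gave a 1.8-fold higher number from compound 1 to compound 2 (0.27 log units; within the scatter). Compound 3 differs from compound 1 by aminoamino in place of chloro on an aromatic carbon, which is also how the core of compound 3 differs from the core of compound 1; that change gave a 1.3-fold higher number from compound 1 to compound 3 (0.11 log units; within the scatter). The values of compound 2 and compound 3 lie within the scatter of each other, so no order among the three is claimed.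

Compound 4, `CS[C@H]1O[C@@H](n2cnc3c(N)nc(NN)nc32)[C@H](O)[C@@H]1O`, has not yet been measured. It differs from compound 3 by methylsulfanyl in place of methyl on a saturated ring carbon, the same change as from compound 1 to compound 2, in the same surroundings; among the compounds shown it occurs twice. Because that change gave a 1.8-fold higher number from compound 1 to compound 2 (0.27 log units; within the scatter), compound 4 is expected to give about 300000 nM in this assay, with a range from 150000 nM to 600000 nM. The expected step of a 1.6-fold higher number from compound 3 to compound 4 (0.20 log units; within the scatter) rests on that single earlier step alone and remains within the scatter.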

Compound 4, half-maximal inhibitory concentration: 178000 nM
For compound 4 the middle estimate is 1.7-fold (0.23 log units) above the measured one, within the range that was stated.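

In this assay, methylsulfanyl in place of methyl on a saturated ring carbon gave a 1.1-fold lower number from compound 3 to compound 4 (0.02 log units; within the scatter), and aminoamino in place of chloro on an aromatic carbon gave a 1.5-fold lower number from compound 2 to compound 4 (0.18 log units; within the scatter); both steps are within the scatter. Carrying the methylsulfanyl change from one core to the other therefore produced no gap beyond the scatter: the same change on two cores in this assay, a 1.8-fold higher number (0.27 log units; within the scatter) from compound 1 to compound 2 and a 1.1-fold lower number (0.02 log units; within the scatter) from compound 3 to compound 4, 1.9-fold (0.29 log units) apart, within the scatter of two such steps

The aminoamino change reads the same way, but this shows only that no dependence on the core can be seen here, not that either change moves this read-out or that its size is the same on both cores: the same change on two cores in this assay, a 1.3-fold higher number (0.11 log units; within the scatter) from compound 1 to compound 3 and a 1.5-fold lower number (0.18 log units; within the scatter) from compound 2 to compound 4, 1.9-fold (0.29 log units) apart, within the scatter of two such steps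

The compounds shown leave open whether a longer chain such as ethylsulfanyl or an amine on the saturated ring carbon, or a carboxylic acid in place of chloro on the aromatic carbon, would give a step beyond the scatter. They also leave open whether any such step would hold on both cores.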